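A few compounds are considered here, and "the series" means these few. Any claim that something is new, unique, unknown or untested is made for them only; others in the source may bear on it.

In a functional assay on MCF7 cells (Homo sapiens) for inhibition, read by sulforhodamine B assay (on this read-out lower numbers stand for stronger inhibition and higher numbers for weaker inhibition), the compounds share one core and differ in the group on a double-bonded ring carbon. Compound 2 `O=C1C=C(N2CCC2)C(=O)c2c1nc1n2[C@H]2OC[C@@H](O)[C@H]2OC1`, which carries azetidin-1-yl, gives no exact number, only the limit > 16000 nM. Compound 1 `O=C1C(Nc2ccccc2)=CC(=O)c2c1nc1n2[C@H]2OC[C@@H](O)[C@H]2OC1` is likewise reported only as a limit, > 4000 nM. With methoxy in place of hydrogen on an aromatic carbon of compound 1, compound 3 `COc1ccccc1NC1=CC(=O)c2c(nc3n2[C@H]2OC[C@@H](O)[C@H]2OC3)C1=O` gives a real number, 6580 nM. That methoxy change is a step that the limit leaves unreadable from compound 1 to compound 3. The change now in view is cyclopentylamino in place of azetidin-1-yl on a double-bonded ring carbon, which gives compound 4 `O=C1C=C(NC2CCCC2)C(=O)c2c1nc1n2[C@H]2OC[C@@H](O)[C@H]2OC1`, with cyclopentylamino in place of azetidin-1-yl on a double-bonded ring carbon. Among the compounds with values here, no measured step covers this swap, so the closest guide is compound 3, which also has a substituted amino group at that carbon and gives 6580 nM. The estimated change is an at least 2.0-fold lower number from compound 2 to compound 4 (0.30 log units; that floor lies within the scatter), towards stronger inhibition, and it remains loose since its starting point is only a limit. For compound 4 the expected value is 8000 nM, with an estimated range of 2500 nM to 20000 nM.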

Compound 4, half-maximal inhibitory concentration: > 16000 nM
Compound 4 ended at the assay's limit; the forecaster's own chance of this, stated with the estimate: 35%; middle value at least 2.0-fold (0.30 log units) away from the limit.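

In this assay compound 2 and compound 4 are both reported only as limits, so cyclopentylamino in place of azetidin-1-yl gives no readable step: the limit of > 16000 nM in this assay, at which 2 of the 4 values shown sit.

The compounds shown leave open how far either compound lies beyond that limit, and whether the swap changes inhibition at all.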